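The source may hold more compounds than are shown below. What is called first, only, known or untested is meant among the compounds shown, and "the series" means these compounds.

Of the compounds shown here, three of one shared core have been measured in a functional assay on MKN-74 cells (Homo sapiens) for antiproliferative activity, with a stated time of 24 h; a lower number here means a stronger inhibitor, a higher number a weaker inhibitor. Compound 1 `NC(=O)c1c(NC(=O)c2ccccc2Cl)sc2c1CCN(Cc1ccc(Cl)cc1)C2` gives 18700 nM. Compound 2 `NC(=O)c1c(NC(=O)c2ccccc2F)sc2c1CCN(Cc1cccc(Cl)c1)C2` gives 23300 nM. Compound 3 `NC(=O)c1c(NC(=O)c2ccccc2F)sc2c1CCN(Cc1ccc(Cl)cc1Cl)C2` gives 9610 nM. Among these three numbers compound 1 stands second highest; its nearest neighbour is compound 2, and the gap between them lies within the scatter, while compound 3 sits furthest from it, at a distance that is still within the scatter. Within the data shown here, the one step between measured compounds that differ in a single place is a 2.4-fold lower number from compound 2 to compound 3 (0.38 log units; beyond the scatter), a modest change on the aromatic ring bound to the saturated chain carbon on the ring amine nitrogen.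

Compound 4 `NC(=O)c1c(NC(=O)c2ccccc2Cl)sc2c1CCN(C(=S)Nc1cccnc1)C2` is not yet measured. It differs from compound 1 as follows: a group of 9 heavy atoms (6 carbon, 2 nitrogen, 1 sulfur; one six-membered aromatic ring with 1 hetero atom) in place of a group of 8 heavy atoms (7 carbon, 1 chlorine; one six-membered aromatic ring of carbon only), on an amine nitrogen in a ring. Among the measured compounds shown here, this change removes the whole 4-chlorobenzyl group and replaces it with a group of nine heavy atoms bearing a six-membered aromatic ring with one hetero atom, so the only measured step, which merely moved chlorine atoms on an otherwise kept benzyl, bears on it weakly at best. For the measured compounds named here, with no direct precedent, the expected step in this assay is a 1.2-fold lower number from compound 1 to compound 4 (0.10 log units; within the scatter), that is, none beyond the scatter. Compound 4 is therefore expected to give about 15000 nM, in a range from 4000 nM to 55000 nM.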

Compound 4, half-maximal inhibitory concentration: 38600 nM
Compound 4: the middle estimate sits 2.6-fold (0.41 log units) below what was measured, and the stated range covers the measured number.
By their numbers in this assay, from the lowest: compounds 3, 1, 2 and 4 (each within the scatter of the next, the first and the last beyond it).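

Among these compounds, until this result, the amine nitrogen in a ring had carried only chlorinated benzyl groups, so the earlier compounds showed only what a change in the chlorine atoms on that benzyl does, and nothing of what happens when the whole group is exchanged. In this assay, replacing the 4-chlorobenzyl group with the group of 9 heavy atoms, which brings a six-membered aromatic ring with 1 hetero atom and 1 hydrogen-bond donor, is a 2.1-fold higher number from compound 1 to compound 4 (0.31 log units; beyond the scatter); at this position, then, the benzyl group can give way to a quite different group at the cost of only a modest step. Nothing measured here accounts for that step or ties it to any one feature of the entering group.

The compounds shown leave open which part of the entering group carries the step, as a change of its sulfur to oxygen or of its ring to a phenyl ring would show. They also leave open whether a small group such as methyl or acetyl on the same nitrogen would give a number close to that of compound 1 or a much higher one.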